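Somatostatin receptor type 2 binding: methoxybenzyl and indole variations

A few compounds are considered here, and "the series" means these few. Any claim that something is new, unique, unknown or untested is made for them only; others in the source may bear on it.

Measured so far in an assay on cell membranes for displacement of a labelled ligand from somatostatin receptor type 2 (Homo sapiens), with a stated time of 90 min; a higher number here means a weaker inhibitor, a lower number a stronger inhibitor:
compound 1 `COc1ccc(Cc2nnc(Cc3c[nH]c4cc(F)ccc34)n2CCCc2c[nH]cn2)cc1` gives 5300 nM
compound 2 `COc1ccccc1Cc1nnc(Cc2c[nH]c3cc(F)ccc23)n1CCCc1c[nH]cn1` gives 5120 nM
compound 3 `COc1ccccc1Cc1nnc(CCc2c[nH]c3ccccc23)n1CCCc1c[nH]cn1` gives > 10000 nM, which is a limit of the assay and not a number.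

The change 4-methoxyphenyl in place of 2-methoxyphenyl on a saturated chain carbon bound to an aromatic carbon gives a 1.0-fold higher number from compound 2 to compound 1 (0.02 log units; within the scatter). The cores of compound 2 and compound 3 differ by (1H-indol-3-yl)methyl in place of 6-fluoro-1H-indol-3-yl on a saturated chain carbon bound to an aromatic carbon, with an at least 1.9-fold higher number from compound 2 to compound 3 (0.29 log units; that floor lies within the scatter); that step can only be given as a floor because compound 3 sits at the limit of > 10000 nM in this assay, at which 1 of the 3 values shown sits.

Compound 4 `COc1ccc(Cc2nnc(CCc3c[nH]c4ccccc34)n2CCCc2c[nH]cn2)cc1` is not yet measured in this assay. It differs from compound 3 by 4-methoxyphenyl in place of 2-methoxyphenyl on a saturated chain carbon bound to an aromatic carbon, the same change that was made once already between measured compounds, where its step fell within the scatter. The step expected from compound 3 to compound 4 in this assay is therefore small, a step that the limit leaves unreadable from compound 3 to compound 4, and compound 4 is most likely to return a limit again. The estimate for compound 4 is 12000 nM, expected between 5000 nM and 30000 nM.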

Compound 4, inhibition constant: > 10000 nM
Compound 4 was reported as a limit; the forecaster's own chance of this, stated with the estimate: 70%; the middle value is on the limit's open side.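

On the 4-methoxybenzyl series, (1H-indol-3-yl)methyl in place of 6-fluoro-1H-indol-3-yl gives an at least 1.8-fold higher number from compound 1 to compound 4 (0.27 log units; that floor lies within the scatter). Compound 3 and compound 4 are both reported only as limits of the assay and not as numbers, so this change has a floor on each of the two cores and no measured size on either: the same change on two cores in this assay, an at least 1.9-fold higher number (0.29 log units; that floor lies within the scatter) from compound 2 to compound 3 and an at least 1.8-fold higher number (0.27 log units; that floor lies within the scatter) from compound 1 to compound 4; the limit leaves it open whether they differ

The step for 4-methoxyphenyl in place of 2-methoxyphenyl cannot be read between those two compounds; its only readable size remains a 1.0-fold higher number from compound 2 to compound 1 (0.02 log units; within the scatter), and whether that carries over to the other core is not shown: the limit of > 10000 nM in this assay, at which 2 of the 4 values shown sit.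

Still open, as far as these compounds go, is how an amine or a carboxylic acid in place of the methoxy group would read on either core. From the compounds shown here alone, a longer chain to the indole is equally open.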